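Two Benzamides Measured, a Third Awaiting Its Number

The compounds below may be only part of what the source reports. "The series", "measured", "known", "first", "only" and "open" are said of these compounds alone.

Compound 1: `COc1cc(N)c(Cl)cc1C(=O)NC1CCN(CCCCCCCCS(=O)(=O)O)CC1`, 1000 nM.
Compound 2: `COc1cc(N)c(Cl)cc1C(=O)NC1CCN(CCCCCN2CCCCC2)CC1`, 5.01 nM.

For the measured compounds named here, in a functional assay on HEK293 cells for agonist activity at 5-hydroxytryptamine receptor 4 (Homo sapiens), read by cAMP accumulation (on this read-out higher numbers stand for an effect only at larger amounts of compound and lower numbers for an effect already at smaller amounts), compound 2 stands lowest of the two numbers so far, and its nearest neighbour is compound 1, separated by a 200-fold lower number from compound 1 to compound 2 (2.30 log units; beyond the scatter). Compound 3, `COc1cc(N)c(Cl)cc1C(=O)NC1CCN(CCN2CCN(S(C)(=O)=O)CC2)CC1`, differs from compound 2 by 4-(methylsulfonyl)piperazin-1-yl in place of 3-(piperidin-1-yl)propyl on a saturated chain carbon, two bonds along the chain from an amine nitrogen in a ring. Going by the values given here, the single measured step bears on this only loosely: it pairs a group without net charge against a sulfonate, whereas here both groups carry no net charge. A smaller rise than that step is therefore expected, namely a 6.0-fold higher number from compound 2 to compound 3 (0.78 log units; beyond the scatter), so compound 3 is estimated at 30 nM within 6 nM to 150 nM.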

Compound 3, half-maximal effective concentration: 20 nM
The estimate for compound 3 lay 1.5-fold (0.18 log units) above the measured number; the range from low to high includes it.
By their numbers in this assay, from the lowest: compound 2; then compound 3; then compound 1.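

Replacing 3-(piperidin-1-yl)propyl with 4-(methylsulfonyl)piperazin-1-yl at this saturated chain carbon gives a 4.0-fold higher number from compound 2 to compound 3 (0.60 log units; beyond the scatter) in this assay and so shows that a sulfur-bearing group with no net charge can stand here at a modest cost. Against the charged sulfonate chain, the same group gives a 50-fold lower number from compound 1 to compound 3 (1.70 log units; beyond the scatter) and stays much closer to compound 2 than to compound 1. No evidence here explains either step.

The compounds shown leave open whether the methylsulfonyl group, the second ring nitrogen or the chain length sets the rise. A 4-acetylpiperazin-1-yl or 4-methylpiperazin-1-yl group on the same chain would help separate these.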